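Aryl ether chain variation in the phenylpropanoic acid series

The source may report more compounds than this note shows. Statements on the series, on what has been measured and on what is new or still open speak of the compounds shown alone.

Among the compounds with values here, compound 2 `COCCCOc1ccc(C(CC(=O)O)c2ccccc2)cc1` stands highest of the two numbers measured so far in a functional assay on HEK293 cells for agonist activity at Free fatty acid receptor 1 (Homo sapiens), read by calcium flux; a lower number here means that less compound is needed, a higher number that more compound is needed for the effect: compound 2 gives 7.58 uM, while compound 1 `O=C(O)CC(c1ccccc1)c1ccc(OCCCC(F)(F)F)cc1` gives 3.16 uM. Within the data shown here, the only measured step, a 2.4-fold higher number from compound 1 to compound 2 (0.38 log units; beyond the scatter), concerns the far end of the same chain. Compound 3 `CCC(CC)COc1ccc(C(CC(=O)O)c2ccccc2)cc1` carries pentan-3-yl in place of 2-methoxyethyl on a saturated chain carbon bound to an oxygen on an aromatic ring. With the acceptor gone, the earlier step is read as pointing back toward a lower number, so a modest decrease is expected in this assay. For compound 3 the value in this assay is estimated at 3.5 uM, within 1.2 uM to 10 uM. This estimate means an expected step of a 2.2-fold lower number from compound 2 to compound 3 (0.34 log units; beyond the scatter).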

Compound 3, concentration for half-maximal effect: 0.64 uM
Compound 3: middle estimate off by 5.5-fold (0.74 log units), on the high side, and the stated range ends above it.
By their numbers in this assay, from the lowest: compound 3; then compound 1; then compound 2.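

Putting pentan-3-yl in place of 2-methoxyethyl on a saturated chain carbon bound to an oxygen on an aromatic ring gives a 12-fold lower number from compound 2 to compound 3 (1.07 log units; beyond the scatter) in this assay, a far larger step than the earlier change at the far end of the chain. In place of 3,3,3-trifluoropropyl, the same group gives a 4.9-fold lower number from compound 1 to compound 3 (0.69 log units; beyond the scatter), so the trifluoromethyl end does not match the 2-ethylbutoxy chain either. No supporting data bear on the size of these steps.

From the compounds shown here alone, whether the lower numbers follow the branching of the 2-ethylbutyl chain or the loss of the ether oxygen remains open. A straight hexyl chain would separate the two, and a cyclopentylmethyl group would test a closed form of the branch.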